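Shortening the Side Chain on a Histone Acetyltransferase Binder

The compounds below may be only part of what the source reports. "The series", "measured", "known", "first", "only" and "open" are said of these compounds alone.

Compound 1 `C=CCCn1c(N[C@@H]2C[C@H](c3ccccc3)CN(C)C2)nc2cc[nH]c2c1=O` is the only one of the two with a number in an assay on isolated protein for binding affinity to histone acetyltransferase KAT2B (Homo sapiens), read by isothermal titration calorimetry; on this read-out lower numbers stand for tighter binding and higher numbers for weaker binding: compound 1 gives 3410 nM. Compound 2 `CN1C[C@H](Nc2nc3ccn(C)c3c(=O)n2C)C[C@H](c2ccccc2)C1` reaches only a limit of the assay; in this assay compound 2 shows > 10000 nM, which sits at the limit of > 10000 nM in this assay, at which 1 of the 2 values shown sits. Compound 3 `CCn1c(N[C@@H]2C[C@H](c3ccccc3)CN(C)C2)nc2cc[nH]c2c1=O` differs from compound 1 by hydrogen in place of vinyl on a saturated chain carbon, two bonds along the chain from an aromatic nitrogen, a change that cuts the but-3-en-1-yl chain back to ethyl. Going by the values given here, with no measured pair of this kind to lean on, a modest weakening is expected, so the step of a 1.6-fold higher number from compound 1 to compound 3 (0.21 log units; within the scatter) is estimated to lie near the edge of the scatter. Compound 3 is therefore expected to give 5500 nM, within 2000 nM to 15000 nM.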

Compound 3, dissociation constant: 621 nM
Beside the measured number, compound 3's estimate is 8.9-fold (0.95 log units) above it, and the stated range ends above it.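

In this assay, cutting the but-3-en-1-yl chain back to ethyl gives a 5.5-fold lower number from compound 1 to compound 3 (0.74 log units; beyond the scatter), so this position responds to the change and the longer chain is not needed for binding. The change removes both chain length and the double bond, and this single step cannot separate the two. Nothing shown accounts for the size of the step.

As far as these compounds go, it remains open whether a saturated butyl chain would behave like the but-3-en-1-yl chain. Also open, from the compounds shown here alone, is whether propyl or methyl at this position would bind more tightly or more weakly than ethyl.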